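Taking the azido group off a well-tolerated compound

A few compounds are considered here, and "the series" means these few. Any claim that something is new, unique, unknown or untested is made for them only; others in the source may bear on it.

Measured in an ADME assay on Huh-7 cells (Homo sapiens) for cytotoxicity, read by thymidine incorporation; a lower number here means that less compound is tolerated, a higher number that more compound is tolerated:
Compound 1 `CCc1cn([C@H]2C[C@H](N=[N+]=[N-])[C@@H](CO)O2)c(=O)[nH]c1=O`: > 100 ug/mL
Compound 2 `[N-]=[N+]=N[C@H]1C[C@H](n2cc(Br)c(=O)[nH]c2=O)O[C@@H]1CO`: > 100 ug/mL

Neither value is an exact number, and compound 1 stands at the assay's limit, as does compound 2: the limit of > 100 ug/mL in this assay, at which 2 of the 2 values shown sit. Compound 3 `CCc1cn([C@H]2CC[C@@H](CO)O2)c(=O)[nH]c1=O` has hydrogen in place of azido on a saturated ring carbon. For the measured compounds named here, the only measured step, a step that the two limits leave unreadable from compound 1 to compound 2, changes a different place and has no readable size. With so little to go on, no step beyond the scatter is expected in this assay. This estimate means a step that the limit leaves unreadable from compound 1 to compound 3. For compound 3 the expected value is 150 ug/mL, with an estimated range of 60 ug/mL to 400 ug/mL.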

Compound 3, half-maximal cytotoxic concentration: > 100 ug/mL
Compound 3: no number, only a limit; the forecaster's own chance of this, stated with the estimate: 85%; the middle value lies beyond the limit too.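

No step can be read from compound 1 to compound 3, because both stop at a limit, not a number: the limit of > 100 ug/mL in this assay, at which 3 of the 3 values shown sit. From the compounds shown here alone, whether hydrogen in place of azido changes how much compound is tolerated stays open.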